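Swapping ethoxy for methyl on a growth inhibitor

The compounds below may be only part of what the source reports. "The series", "measured", "known", "first", "only" and "open" are said of these compounds alone.

In a functional assay on HepG2 cells (Homo sapiens) for antiproliferative activity, read by MTT assay, with a stated time of 48 h (a lower number here means a stronger inhibitor of growth, a higher number a weaker inhibitor of growth), the compounds stand as follows.
Compound 1 `COC(=O)N1N=C(c2cccc(O)c2)CC1c1cc(OC)c(OC)c(OC)c1` gives 650 nM in this series.
Compound 2 `CCOc1cccc(C2=NN(C(=O)OC)C(c3cc(OC)c(OC)c(OC)c3)C2)c1` gives 8360 nM in this series.
Compound 3 `COC(=O)N1N=C(c2cccc(C)c2)CC1c1cc(OC)c(OC)c(OC)c1` has not yet been measured.

Compound 2 holds the higher number of the two measured compounds, and so it is the weaker inhibitor of growth of the pair. The change to compound 3 is methyl in place of ethoxy on an aromatic carbon with the rest of the structure kept. Among the measured compounds shown here, one measured step bears on this place. It reads a 13-fold higher number from compound 1 to compound 2 (1.11 log units; beyond the scatter) and came with ethyl in place of hydrogen on an oxygen on an aromatic ring, so a large shift has already been seen from a change in this group. For the measured compounds named here, no compound with methyl here has been measured, so that step is only a guide, and compound 3 is expected to win back part of it rather than all. The expected move is a 3.3-fold lower number from compound 2 to compound 3 (0.52 log units; beyond the scatter) in the direction of a lower number, a smaller step than the measured one. For compound 3 the estimated value is 2500 nM with an expected range of 700 nM to 8000 nM around it.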

Compound 3, concentration for 50% growth inhibition: 980 nM
Beside the measured number, compound 3's estimate is 2.6-fold (0.41 log units) above it, and the stated range covers the measured number.
By their numbers in this assay, from the lowest: compounds 1 and 3 (each within the scatter of the next); then compound 2.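

In this assay, methyl in place of ethoxy on this aromatic carbon gives an 8.5-fold lower number from compound 2 to compound 3 (0.93 log units; beyond the scatter), which shows that the weak growth inhibition of compound 2 does not extend to every group that replaces the hydroxy of compound 1. Methyl in place of hydroxy gives a 1.5-fold higher number from compound 1 to compound 3 (0.18 log units; within the scatter), within the scatter, so this position tolerates either group in this assay, and among the three compounds only the ethoxy compound stands apart. The data offer no independent measurement that accounts for this difference between ethoxy and the other two groups.

What the compounds shown leave open is where between methyl and ethoxy the number begins to rise, since methoxy and ethyl could fall on either side of that divide. They also leave open how an amine or a carboxylic acid at this place would compare, and whether a longer chain such as propoxy would raise the number beyond that of compound 2.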